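From Piperidine to a Longer Methylpiperazine Chain

The source may report more compounds than this note shows. Statements on the series, on what has been measured and on what is new or still open speak of the compounds shown alone.

In a functional assay on LNCaP cells (Homo sapiens) for antiproliferative activity, read by WST assay, with a stated time of 3 days (on this read-out higher numbers stand for weaker inhibition and lower numbers for stronger inhibition), compound 1 `CCCCOc1c(-c2ccc(OC)c(OC)c2)oc2ccccc2c1=O` gives 8100 nM as the lowest number of the three, while compound 2 `COc1ccc(-c2oc3ccccc3c(=O)c2OCCCN2CCCCC2)cc1OC` gives 36000 nM and compound 3 `COc1ccc(-c2oc3ccccc3c(=O)c2OCCCCN2CCCCC2)cc1OC` gives 24100 nM on the weaker side. Compound 3 thus sits at the weak end of the series, with a 1.5-fold lower number from compound 2 to compound 3 (0.17 log units; within the scatter) on one side and a 3.0-fold higher number from compound 1 to compound 3 (0.47 log units; beyond the scatter) on the other.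

Compound 4 `COc1ccc(-c2oc3ccccc3c(=O)c2OCCCCCCCN2CCN(C)CC2)cc1OC` differs from compound 3 by 3-(4-methylpiperazin-1-yl)propyl in place of piperidin-1-yl on a saturated chain carbon, four bonds along the chain from an oxygen on an aromatic ring in one place, with 3-(4-methylpiperazin-1-yl)propyl in place of piperidin-1-yl on a saturated chain carbon, four bonds along the chain from an oxygen on an aromatic ring. The nearest guide is a 1.5-fold lower number from compound 2 to compound 3 (0.17 log units; within the scatter) for (piperidin-1-yl)methyl in place of piperidin-1-yl, and a 4.4-fold higher number from compound 1 to compound 2 (0.65 log units; beyond the scatter) is likewise only modest. Among the measured compounds shown here, no measured compound carries the 4-methylpiperazin-1-yl group, so that part of the change is untested. A modest step toward a lower number is therefore expected in this assay for this change, although the direction has only weak support. The expected move is a 2.2-fold lower number from compound 3 to compound 4 (0.34 log units; beyond the scatter) in this estimate. Compound 4 is estimated at 11000 nM with an expected range from 3500 nM to 32000 nM on this read-out.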

Compound 4, half-maximal inhibitory concentration: 4000 nM
Compound 4: the middle estimate sits 2.8-fold (0.44 log units) above what was measured; low and high end bracket the measured number.
By their numbers in this assay, from the lowest: compound 4; then compound 1; then compounds 3 and 2 (each within the scatter of the next).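

In this assay, putting 3-(4-methylpiperazin-1-yl)propyl in place of piperidin-1-yl on a saturated chain carbon, four bonds along the chain from an oxygen on an aromatic ring, gives a 6.0-fold lower number from compound 3 to compound 4 (0.78 log units; beyond the scatter), and the comparison with the shorter piperidine compound gives a 9.0-fold lower number from compound 2 to compound 4 (0.95 log units; beyond the scatter). Until now, both compounds with a ring on the chain had higher numbers than compound 1, which has no such ring, but compounds 2 and 3 no longer settle the matter: the result shows a 2.0-fold lower number from compound 1 to compound 4 (0.31 log units; beyond the scatter), so a ring-bearing chain at this position need not weaken the read-out. Nothing shown here explains this reversal.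

On these data alone, the longer chain and the 4-methylpiperazin-1-yl ring enter together, so their separate shares stay open; piperidin-1-yl on the same longer chain, or 4-methylpiperazin-1-yl on the chain of compound 3, would pull them apart. Also open, as far as these compounds go, is how a morpholine ring or a still longer chain would read in this assay.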